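The source may report more compounds than this note shows. Statements on the series, on what has been measured and on what is new or still open speak of the compounds shown alone.

Measured so far in a functional assay (trachea) for antagonist activity, with Cavia porcellus as the target; a lower number here means a less potent compound, a higher number a more potent compound, by a factor of ten per unit of this negative logarithm:

Compound 1, `CCCCC(CC)C(=O)Nc1ccc2ccn(Cc3ccc(C(=O)NS(=O)(=O)c4ccc(Cl)cc4)cc3OC)c2c1`, gives 7.8.
Compound 2, `CCCCC(CC)C(=O)Nc1ccc2ccn(Cc3ccc(C(=O)NS(=O)(=O)c4ccccc4)cc3OC)c2c1`, gives 8.6.
Compound 3, `CCCCC(CC)C(=O)Nc1ccc2ccn(Cc3ccc(C(=O)NS(=O)(=O)c4ccc([N+](=O)[O-])cc4)cc3OC)c2c1`, gives 7.7.

Compound 3 carries the lowest number of the three. Its nearest neighbour is compound 1, since a number 0.10 log units lower from compound 1 to compound 3 (within the scatter), a gap within the scatter; the step of a number 0.90 log units lower from compound 2 to compound 3 (beyond the scatter) lies beyond the scatter and sets compound 3 clearly apart from compound 2. The new compound 4, `CCCCC(CC)C(=O)Nc1ccc2ccn(Cc3ccc(C(=O)NS(=O)(=O)c4ccccc4C)cc3OC)c2c1`, differs from compound 3 in one place: 2-methylphenyl in place of 4-nitrophenyl on a sulfonyl sulfur. Among the compounds with values here, two measured steps bear on this. The step of a number 0.90 log units lower from compound 2 to compound 3 (beyond the scatter) shows what the nitro group costs; the step of a number 0.80 log units higher from compound 1 to compound 2 (beyond the scatter) shows the bare phenyl outscoring a substituted one. Removing the nitro should therefore recover most of that loss, while nothing measured here tells what a 2-methylphenyl adds or takes away. The step from compound 3 to compound 4 is expected to be upward, about a number 0.60 log units higher from compound 3 to compound 4 (beyond the scatter) in this assay. Compound 4 is thus estimated at 8.3, with a range from 7.6 to 9.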

Compound 4, negative logarithm of the antagonist equilibrium constant: 8.9
Estimate against measurement, compound 4: 0.60 log units below, and the stated range covers the measured number.
By their numbers in this assay, from the lowest: compounds 3 and 1 (each within the scatter of the next); then compounds 2 and 4 (each within the scatter of the next).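

The aryl group on the sulfonyl sulfur can carry a substituent without a loss: in this assay, the change to 2-methylphenyl brings a number 1.20 log units higher from compound 3 to compound 4 (beyond the scatter) from the 4-nitrophenyl group and a number 1.10 log units higher from compound 1 to compound 4 (beyond the scatter) from the 4-chlorophenyl group. Set against the unsubstituted phenyl, the added methyl gives a number 0.30 log units higher from compound 2 to compound 4 (within the scatter), so the drop seen with chloro and nitro does not extend to every substituent on this ring, and compound 4 stands level with compound 2 rather than with compound 1 or compound 3. No measured evidence accompanies these numbers to explain the difference between the groups.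

The compounds shown leave open how other groups on this ring, such as an ethyl, a methoxy or an amine, would compare with the methyl. They also leave open whether a longer chain in place of the methyl would keep the level of compound 4.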